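This account rests on a few compounds, and the source may have more. Where it says the series, first, only, none or still open, it means among the compounds named here.

Series notes. Compound 1 `Cc1c(Cc2ccccc2)c(=O)oc2cc(OCC(O)CNc3ccccc3)ccc12` in an ADME assay on A549 cells (Homo sapiens) for cytotoxicity, read by CellTiter-Glo (on this read-out lower numbers stand for higher toxicity in this test and higher numbers for lower toxicity in this test), returns only the assay limit, > 100000 nM, a limit rather than a number (the limit of > 100000 nM in this assay, at which 1 of the 3 values shown sits). Compound 2 `Cc1c(Cc2ccccc2)c(=O)oc2cc(OCC(O)CNCc3cccs3)ccc12` gives 87300 nM. Compound 3 `Cc1c(Cc2ccc(Cl)cc2)c(=O)oc2cc(OCC(O)CN3CCC(C(N)=O)CC3)ccc12` gives 40000 nM, the lowest of the two numbers shown; its nearest neighbour is compound 2, at a higher figure beyond the usual scatter. Among the measured compounds shown here, the single measured step, an at least 1.1-fold lower number from compound 1 to compound 2 (0.05 log units; that floor lies within the scatter), concerns the amine nitrogen and starts from a limit. Compound 4 `Cc1c(Cc2ccc(F)cc2Cl)c(=O)oc2cc(OCC(O)CN3CCC(C(N)=O)CC3)ccc12` differs from compound 3 by 2-chloro-4-fluorophenyl in place of 4-chlorophenyl on a saturated chain carbon bound to an aromatic carbon. For the measured compounds named here, no measured step touches the 4-chlorobenzyl group, so no measured guidance exists for this change. The step expected no change at the digits printed from compound 3 to compound 4 (within the scatter) is therefore none beyond the scatter. For compound 4 the estimate in this assay is 40000 nM, within 15000 nM to 100000 nM.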

Compound 4, half-maximal cytotoxic concentration: 90800 nM
Estimate against measurement, compound 4: 2.3-fold (0.36 log units) below, and the stated range covers the measured number.
By their numbers in this assay, from the lowest: compound 3; then compounds 2 and 4 (each within the scatter of the next). At a limit, above all of these: compound 1.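

In this assay, the place on a saturated chain carbon bound to an aromatic carbon now has a measured step: 2-chloro-4-fluorophenyl in place of 4-chlorophenyl gives a 2.3-fold higher number from compound 3 to compound 4 (0.36 log units; beyond the scatter). The earlier compounds shown here held no step here, and this one shows that the aromatic group at this place can shift the read-out while the rest of the molecule stays the same. Nothing measured bears on why the number moves.

Open, on these data alone, is which of the two halogens carries the step, and how a 2-chlorophenyl or 4-fluorophenyl group would read at this place. Also open, as far as these compounds go, is whether the step holds with the (thiophen-2-yl)methyl amine of compound 2 in place of the amide-bearing amine.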